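The source may hold more compounds than are shown below. What is called first, only, known or untested is meant among the compounds shown, and "the series" means these compounds.

Measured so far in an assay on isolated protein for inhibition of Amine oxidase [flavin-containing] A (Homo sapiens); a lower number here means a stronger inhibitor, a higher number a weaker inhibitor:
compound 1, `CN(C)c1ccc(/C=C/C(=O)c2ccc(N(C)C)cc2O)cc1`, gives 47900 nM
compound 2, `CCN(CC)CCCOc1ccc(C(=O)/C=C/c2ccc(N(C)C)cc2)c(O)c1`, gives 47100 nM

Compound 2 stands within the scatter of compound 1; the two numbers cannot be told apart, and neither compound can be called the stronger. For the measured compounds named here, the one measured step, a 1.0-fold lower number from compound 1 to compound 2 (0.01 log units; within the scatter), left the reading unchanged although it exchanged a dimethylamino on an aromatic carbon for a 3-(diethylamino)propoxy.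

Compound 3, `COc1ccc(C(=O)/C=C/c2ccc(N(C)C)cc2)c(O)c1`, follows from compound 2 by hydrogen in place of 2-(diethylamino)ethyl on a saturated chain carbon bound to an oxygen on an aromatic ring. The same chain that was installed in the measured step is here cut back to a methoxy. Going by the values given here, the only step that bears on this is a 1.0-fold lower number from compound 1 to compound 2 (0.01 log units; within the scatter), which shows that presence or absence of this chain moved nothing beyond the scatter, so in this assay no step beyond the scatter is expected for compound 3 either. The step expected is a 1.0-fold lower number from compound 2 to compound 3 (0.00 log units; within the scatter). Compound 3 is therefore estimated at 47000 nM, with a range from 20000 nM to 110000 nM.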

Compound 3, half-maximal inhibitory concentration: 7620 nM
The estimate for compound 3 lay 6.2-fold (0.79 log units) above the measured number; measured number outside the range, below it.
By their numbers in this assay, from the lowest: compound 3; then compounds 2 and 1 (each within the scatter of the next).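

In this assay the position does respond to what it carries: cutting 3-(diethylamino)propoxy back to methoxy gives a 6.2-fold lower number from compound 2 to compound 3 (0.79 log units; beyond the scatter), a step beyond the scatter that the earlier comparison gave no sign of. Methoxy in place of dimethylamino on an aromatic carbon gives a 6.3-fold lower number from compound 1 to compound 3 (0.80 log units; beyond the scatter), so methoxy stands apart from both other groups, while those two remain within the scatter of each other. Nothing measured here bears on the reason for either step.

Open, going by these compounds, is whether the lower number belongs to the methoxy itself or simply to the absence of an amine at this position. A free hydroxyl, an ethoxy or a longer chain ending without an amine on the same core would separate these two readings.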